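A few compounds are considered here, and "the series" means these few. Any claim that something is new, unique, unknown or untested is made for them only; others in the source may bear on it.

Compound 1 `CC1(C)OC[C@H](Cn2cc(-c3ccc([N+](=O)[O-])cc3)nn2)O1` gives > 100000 nM in a functional assay on B16 cells (Mus musculus) for cytotoxicity, read by MTT assay, with a stated time of 48 h; a lower number here means a stronger inhibitor, a higher number a weaker inhibitor. Compound 2 `O=[N+]([O-])c1ccc(-c2cn(Cc3ccccc3)nn2)cc1` gives 5120 nM in this assay.

Compound 1 stands only at a limit in this assay: its value is a limit of the assay, not a number, as the limit of > 100000 nM in this assay, at which 1 of the 2 values shown sits, states. Going by the values given here, the single measured step, an at least 19-fold lower number from compound 1 to compound 2 (1.29 log units; beyond the scatter), exchanges the group on the saturated chain carbon bound to the aromatic nitrogen and leaves the aromatic ring untouched. Compound 3 `CC1(C)OC[C@H](Cn2cc(-c3ccc(C(F)(F)F)cc3)nn2)O1` differs from compound 1 in a different place: trifluoromethyl in place of nitro on an aromatic carbon. Among the compounds with values here, no measured step bears on this exchange on the aromatic ring, so the measured data give no size for it, and a step in this assay that stays within the scatter, or a modest one in either direction, is the expectation. Compound 3 is therefore estimated at 100000 nM, within 20000 nM to 300000 nM. That estimate means an expected step of a number no higher from compound 1 to compound 3 (the limit leaves the size open).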

Compound 3, half-maximal inhibitory concentration: > 100000 nM
Compound 3: a limit, no number; the forecaster's own chance of this, stated with the estimate: 60%; the middle value sits exactly at the limit.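

Compound 3 gives > 100000 nM in this assay, which is a limit of the assay and not a number. Going by these compounds alone, compound 1 also stands at a limit, so no step between compound 1 and compound 3 can be read: the limit of > 100000 nM in this assay, at which 2 of the 3 values shown sit. The compounds shown leave open how far trifluoromethyl in place of nitro on an aromatic carbon moves the number in this assay.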